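A few compounds are considered here, and "the series" means these few. Any claim that something is new, unique, unknown or untested is made for them only; others in the source may bear on it.

In an assay on cells for inhibition of protein deacetylase HDAC6 (Homo sapiens), read by fluorescence, with a stated time of 24 h (a higher number here means a weaker inhibitor, a lower number a stronger inhibitor), compound 1 `C[C@H](NC(=O)c1nc(-c2ncc(-c3ccc(F)cc3)s2)sc1C1CC1)c1ccc(C(=O)NO)cc1` gives 2.02 nM, and compound 2 `C[C@H](NC(=O)c1nc(-c2nc3c(s2)CCCC3)sc1C1CC1)c1ccc(C(=O)NO)cc1` gives 18.3 nM. Of these two numbers compound 2 holds the higher one, and the gap from compound 1 lies beyond the usual scatter. Compound 3 `Cc1cnc(-c2nc(C(=O)N[C@@H](C)c3ccc(C(=O)NO)cc3)c(C3CC3)s2)s1` differs from compound 2 in one place: a group of 6 heavy atoms (4 carbon, 1 nitrogen, 1 sulfur; one five-membered aromatic ring with 2 hetero atoms) in place of a group of 9 heavy atoms (7 carbon, 1 nitrogen, 1 sulfur; one five-membered aromatic ring with 2 hetero atoms, one six-membered non-aromatic ring of carbon only), on an aromatic carbon. No comparable change has been measured here. Given the value of compound 2 at 18.3 nM, the step from compound 2 to compound 3 is expected to be a 2.0-fold lower number from compound 2 to compound 3 (0.31 log units; beyond the scatter), toward a lower number, but modest enough that it may sit within the scatter. Compound 3 is therefore estimated at 9 nM, with a range from 3 nM to 27 nM.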

Compound 3, half-maximal inhibitory concentration: 18.5 nM
For compound 3 the middle estimate is 2.1-fold (0.31 log units) below the measured one, within the range that was stated.
By their numbers in this assay, from the lowest: compound 1; then compounds 2 and 3 (each within the scatter of the next).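

In this assay, 5-methyl-1,3-thiazol-2-yl in place of the larger two-ring group gives a 1.0-fold higher number from compound 2 to compound 3 (0.00 log units; within the scatter), so losing the six-membered carbon ring changes nothing measurable here. Methyl in place of 4-fluorophenyl gives a 9.2-fold higher number from compound 1 to compound 3 (0.96 log units; beyond the scatter), which shows that the group carried on this outer ring can matter. Nothing measured here explains either step. Still open, on these data alone, is whether plain phenyl would match 4-fluorophenyl, which would show whether the fluorine matters. A group of intermediate size, such as ethyl or cyclopropyl, might also fall between these values.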